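The source may report more compounds than this note shows. Statements on the series, on what has been measured and on what is new or still open speak of the compounds shown alone.

Measured in an ADME assay on BHK cells (Mesocricetus auratus) for cytotoxicity, read by MTT assay, with a stated time of 96 h; on this read-out lower numbers stand for higher toxicity in this test and higher numbers for lower toxicity in this test:
Compound 1 `COc1ccc(-c2nc3cc(Cl)c(Cl)cc3[nH]2)c([N+](=O)[O-])c1`: 80000 nM.
Compound 2 `O=[N+]([O-])c1ccc(-c2nc3cc(C(F)(F)F)ccc3n2C2CCCCC2)cc1`: > 100000 nM, a limit of the assay.
Compound 3 `COc1ccc(-c2nc3cc(Cl)c(Cl)cc3[nH]2)c(N)c1`: > 100000 nM, a limit of the assay.

From compound 1 to compound 3 the change is amino in place of nitro on an aromatic carbon. In this assay it gives an at least 1.2-fold higher number from compound 1 to compound 3 (0.09 log units; that floor lies within the scatter); the floor comes from the limit of > 100000 nM in this assay, at which 2 of the 3 values shown sit. Compound 4 `Nc1ccc(-c2nc3cc(C(F)(F)F)ccc3n2C2CCCCC2)cc1`, not yet measured, carries the same kind of change against compound 2: amino in place of nitro on an aromatic carbon. The surroundings differ: in compound 3 the position is ortho to a large group and meta to a methoxy group, in compound 4 para to a large group. How the core of compound 2 differs from that of compound 1 is not broken down here. Compound 2 sits at the limit > 100000 nM. Beside an at least 1.2-fold higher number from compound 1 to compound 3 (0.09 log units; that floor lies within the scatter), the expected step is a step that the limit leaves unreadable from compound 2 to compound 4, resting on compound 2 already being at that limit. Compound 4 is therefore estimated at 150000 nM in this assay, between 70000 nM and 400000 nM, most likely again reported only as a limit.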

Compound 4, half-maximal cytotoxic concentration: > 100000 nM
Compound 4 was reported as a limit (the forecaster's own chance of this, stated with the estimate: 75%); the middle value is on the limit's open side.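

No step can be read from compound 2 to compound 4 in this assay, since both are reported only as limits: the limit of > 100000 nM in this assay, at which 3 of the 4 values shown sit. On these data alone, whether amino in place of nitro changes the number at all on the core of compound 2 stays open.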